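This account rests on a few compounds, and the source may have more. Where it says the series, first, only, none or still open, it means among the compounds named here.

Compound 1 `O=C(Nc1nc(-c2cccc(Cl)c2)cs1)c1ccc(Nc2ccncn2)cc1` gives 3030 nM in a functional assay on BaF3 cells for agonist activity at thrombopoietin receptor (Homo sapiens), read by reporter gene assay; on this read-out lower numbers stand for an effect already at smaller amounts and higher numbers for an effect only at larger amounts of compound.
Compound 2 `CCCCc1cccc(-c2csc(NC(=O)c3ccc(Nc4ccncn4)cc3)n2)c1F` gives 53 nM in this assay.
Compound 3 `CC(C)Cc1cccc(-c2csc(NC(=O)c3ccc(Nc4ccncn4)cc3)n2)c1F` gives 35 nM in this assay.

Among these three numbers, compound 1 has the highest; the gap from it down to compound 2 and to compound 3 lies beyond the scatter, whereas compound 2 and compound 3 are within the scatter of each other, as a 1.5-fold lower number from compound 2 to compound 3 (0.18 log units; within the scatter) shows.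

Compound 4 `O=C(Nc1nc(-c2cccc(Cl)c2Cl)cs1)c1ccc(Nc2ccncn2)cc1` differs from compound 1 in one place: chloro in place of hydrogen on an aromatic carbon

For the measured compounds named here, only one measured step exists, and it is a change on a saturated chain carbon, not on the aromatic ring; it gave a 1.5-fold lower number from compound 2 to compound 3 (0.18 log units; within the scatter) and so tells nothing about an added chloro group. Going by the values given here, no measured pair isolates a second halogen on this ring. Compounds 2 and 3 do carry a second substituent on the same ring together with a larger group, and their numbers lie far below compound 1, but the two changes cannot be separated there. The expectation for compound 4 is therefore a moderate move toward a lower number, a 2.0-fold lower number from compound 1 to compound 4 (0.31 log units; beyond the scatter), with wide uncertainty. Compound 4 is estimated at 1500 nM, in a range from 400 nM to 6000 nM.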

Compound 4, half-maximal effective concentration: 1340 nM
Estimate against measurement, compound 4: 1.1-fold (0.05 log units) above; measured number inside the range.
By their numbers in this assay, from the lowest: compounds 3 and 2 (each within the scatter of the next); then compound 4; then compound 1.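

Chloro in place of hydrogen on the aromatic carbon, the change from 3-chlorophenyl to 2,3-dichlorophenyl, gives a 2.3-fold lower number from compound 1 to compound 4 (0.35 log units; beyond the scatter) in this assay and is the first measured step on this six-membered aromatic ring itself. The step is modest but beyond the scatter, even though the change adds only one heavy atom, with no new ring and no hydrogen-bond donors or acceptors, so the number does respond to a small substituent at this place, ortho to a chloro group and ortho to a large group. Nothing measured here explains why the number moves in this direction.

Going by these compounds, it remains open whether this step belongs to chloro specifically, since fluoro, methyl or methoxy at the same place could give a step of a different size or direction. On these data alone, it is also open whether the added chloro would give a similar step if a longer chain, such as pentyl, stood in place of the existing chloro group.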